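This account rests on a few compounds, and the source may have more. Where it says the series, first, only, none or still open, it means among the compounds named here.

Compound 1, `CCc1ccccc1NC(=O)N[C@H](C)c1ccccc1`, was examined in an ADME assay on the whole organism with Oryza sativa as the target, tested at 0.1 uM (a lower number here means a stronger effect, a higher number a weaker effect of the compound at the concentration tested), where compound 1 gives 101%. Two close relatives were measured alongside it. Compound 2, `CCc1ccccc1NC(=O)N[C@@H](C)c1ccccc1`, has the same atoms and bonds as compound 1 and differs only in the configuration drawn at one saturated chain carbon; in this assay compound 2 gives 100%. Compound 3, `CCc1cccc(NC(=O)N[C@@H](C)c2ccccc2)c1`, carries its ethyl group at a different position on the ring, and in this assay compound 3 gives 100%. Compound 1 holds the highest of the three numbers, but all three lie within the usual scatter of one another, so no ordering among them can be read. For the measured compounds named here, the single step between compounds differing in one place, a number 1 percentage points lower from compound 1 to compound 2 (within the scatter), is within the scatter, and the structures behind it show only that (the fact that compounds 1 and 2 differ only in the configuration as drawn).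

Compound 4, `C[C@@H](NC(=O)Nc1ccccc1I)c1ccccc1`, is not yet measured. Relative to compound 1 the change is iodo in place of ethyl on an aromatic carbon. Going by the values given here, no measured step addresses an exchange of this kind; the one available step concerns configuration alone. Among the compounds with values here, with every number so far clustered near the top of the scale, the expected step of a number 3 percentage points lower from compound 1 to compound 4 (within the scatter) is small, with no direction beyond the scatter. Compound 4 is therefore estimated to give 98%, with a range from 85% to 105%.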

Compound 4, a percentage reported as activity, at one concentration (the size of the read-out at that concentration, not a potency): 100%
Beside the measured number, compound 4's estimate is 2 percentage points below it, within the range that was stated.
By their numbers in this assay, from the lowest: compounds 2, 3, 4 and 1 (each within the scatter of the next).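

Swapping iodo for ethyl on an aromatic carbon, ortho to a large group, gives in this assay only a number 1 percentage points lower from compound 1 to compound 4 (within the scatter). For the compounds shown here, the earlier compounds showed a change of configuration and a shift of the ethyl group around the ring, while this result is the first to replace the group itself: ethyl, with its two carbons, gives way to a single iodine atom, and the read-out shows no change that can be told from the scatter. At this position on the six-membered aromatic ring, then, the exchange can be made without a readable difference, though this rests on one pair of compounds, and nothing measured on either group bears on why the number holds level.

All four compounds sit together near the top of the scale, so none of them shows what a clearly lower number would take, or which part of the shared core it would depend on. Going by these compounds, whether an amine, a carboxylic acid or a longer chain such as butyl at this position would move the read-out beyond the scatter stays open.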